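Cytotoxicity of a cyanophenyl analogue within a dienone series

The source may report more compounds than this note shows. Statements on the series, on what has been measured and on what is new or still open speak of the compounds shown alone.

Compound 2 `COc1cc(/C=C2\CN(C)C/C(=C\c3ccc(Cl)c(Cl)c3)C2=O)cc(OC)c1` gives 10600 nM in an ADME assay on L02 cells (Homo sapiens) for cytotoxicity, read by MTT assay, with a stated time of 24 h (on this read-out lower numbers stand for stronger inhibition and higher numbers for weaker inhibition), the lowest of the two numbers recorded; compound 1 `COc1cc(/C=C2\CN(C)C/C(=C\c3ccc(F)cc3)C2=O)cc(OC)c1` gives 21900 nM in this assay. Within the data shown here, the one step between measured compounds is a 2.1-fold lower number from compound 1 to compound 2 (0.32 log units; beyond the scatter). Compound 3 `COc1cc(/C=C2\CN(C)C/C(=C\c3ccc(C#N)cc3)C2=O)cc(OC)c1` differs from compound 2 in one place: 4-cyanophenyl in place of 3,4-dichlorophenyl on a double-bonded chain carbon bound to a double-bonded ring carbon. Among the measured compounds shown here, only that single modest step bears on this change, and it concerned a different aryl group, so a small shift toward the weaker end is expected rather than a large one. Compound 3 is therefore estimated at 16000 nM in this assay, within 7000 nM to 36000 nM, a step of a 1.5-fold higher number from compound 2 to compound 3 (0.18 log units; within the scatter).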

Compound 3, half-maximal inhibitory concentration: 14000 nM
Beside the measured number, compound 3's estimate is 1.1-fold (0.06 log units) above it; measured number inside the range.
By their numbers in this assay, from the lowest: compounds 2, 3 and 1 (each within the scatter of the next, the first and the last beyond it).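

In this assay the swap of 3,4-dichlorophenyl for 4-cyanophenyl on a double-bonded chain carbon bound to a double-bonded ring carbon stays within the scatter (a 1.3-fold higher number from compound 2 to compound 3 (0.12 log units; within the scatter)), and so does cyano in place of fluoro on an aromatic carbon (a 1.6-fold lower number from compound 1 to compound 3 (0.19 log units; within the scatter)). Compound 3 therefore cannot be separated from either compound 1 or compound 2, although those two lie beyond the scatter of each other. No measurement shown here offers an explanation for these results. As far as these compounds go, whether an amine or a carboxylic acid on this aromatic ring would give a step beyond the scatter remains open.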